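Aryl Variation on a Shared Core: Cytotoxicity Outlook

The source may report more compounds than this note shows. Statements on the series, on what has been measured and on what is new or still open speak of the compounds shown alone.

Of the compounds shown here, two have been measured in an ADME assay on NIH3T3 cells (Mus musculus) for cytotoxicity, read by MTT assay; on this read-out lower numbers stand for stronger inhibition and higher numbers for weaker inhibition. Compound 1 `N#Cc1c(-c2ccccc2)c(C#N)c(=O)n(/N=C/c2cn(-c3ccccc3)nc2-c2ccccc2)c1N` gives 180 ug/mL in this assay, and compound 2 `N#Cc1c(-c2ccc(O)cc2)c(C#N)c(=O)n(/N=C/c2cn(-c3ccccc3)nc2-c2ccccc2)c1N` gives 110 ug/mL. Within the data shown here, compound 2 holds the lowest of the two numbers, but its only neighbour is compound 1, and the step of a 1.6-fold lower number from compound 1 to compound 2 (0.21 log units; within the scatter) lies within the scatter, so the two compounds cannot be told apart on this read-out.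

Compound 3 `N#Cc1c(-c2ccccc2Cl)c(C#N)c(=O)n(/N=C/c2cn(-c3ccccc3)nc2-c2ccccc2)c1N` differs from compound 2 in one place: 2-chlorophenyl in place of 4-hydroxyphenyl on an aromatic carbon. Among the measured compounds shown here, no measured step touches a chlorine on this aryl group; the only step known, from hydrogen to hydroxy, moved the number by less than the scatter. Compound 3 is therefore expected to give a step of a 1.3-fold higher number from compound 2 to compound 3 (0.10 log units; within the scatter) in this assay, that is, none beyond the scatter, and its estimated value is 140 ug/mL, with a range from 60 ug/mL to 320 ug/mL.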

Compound 3, half-maximal inhibitory concentration: 84 ug/mL
Beside the measured number, compound 3's estimate is 1.7-fold (0.22 log units) above it; the measured number falls inside the stated range.
By their numbers in this assay, from the lowest: compounds 3, 2 and 1 (each within the scatter of the next, the first and the last beyond it).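

Replacing 4-hydroxyphenyl with 2-chlorophenyl at this position, opposite the ring nitrogen, gives a 1.3-fold lower number from compound 2 to compound 3 (0.12 log units; within the scatter), so these two aryl groups cannot be told apart in this assay. Chloro in place of hydrogen on the phenyl group gives the only step in the series that is beyond the scatter, a 2.1-fold lower number from compound 1 to compound 3 (0.33 log units; beyond the scatter), though it is a modest one, which shows that a change to this aryl group can register on this read-out. Nothing available accounts for that step.

As far as these compounds go, whether chloro would give a similar step on another carbon of the phenyl group remains open. So does the outcome with a methoxy group, a carboxylic acid or a dimethylamino group on that ring, or with a cyclohexyl ring in place of the aryl group.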